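From pyridin-3-yl to thiophen-2-yl on a shared core

The source may hold more compounds than are shown below. What is called first, only, known or untested is meant among the compounds shown, and "the series" means these compounds.

Compound 1 `COC(=O)C1=C(C)NC(C)=C(C(=O)OC)C1c1c(-c2cccnc2)nc2sc(C)cn12`: 12500 nM
Compound 2 `COC(=O)C1=C(C)NC(C)=C(C(=O)OC)C1c1c(-c2ccccn2)nc2sc(C)cn12`: 39900 nM
Compound 3 `COC(=O)C1=C(C)NC(C)=C(C(=O)OC)C1c1c(-c2c(Cl)csc2Cl)nc2sccn12`: 2160 nM

In a functional assay on cardiac atrium (Cavia porcellus) (on this read-out lower numbers stand for an effect already at smaller amounts and higher numbers for an effect only at larger amounts of compound), compound 1 gives 12500 nM, the second highest of the three numbers. Compound 4 `COC(=O)C1=C(C)NC(C)=C(C(=O)OC)C1c1c(-c2cccs2)nc2sc(C)cn12` carries thiophen-2-yl in place of pyridin-3-yl on an aromatic carbon. Within the data shown here, only one measured step changes this group alone: a 3.2-fold higher number from compound 1 to compound 2 (0.50 log units; beyond the scatter). It swaps one pyridine for another, so it is a guide to size only, and no thiophen-2-yl has been measured. Compound 3 gives 2160 nM, but it differs from compound 1 in more than one place, and its group here is no pyridine either. It supports only a slight lean to a lower number. The expected change is small: a 1.7-fold lower number from compound 1 to compound 4 (0.22 log units; within the scatter). For compound 4 the estimated value is 7500 nM, with an expected range from 2200 nM to 25000 nM.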

Compound 4, half-maximal effective concentration: 40500 nM
Estimate against measurement, compound 4: 5.4-fold (0.73 log units) below; measured number outside the range, above it.
By their numbers in this assay, from the lowest: compound 3; then compound 1; then compounds 2 and 4 (each within the scatter of the next).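

In this assay the change to thiophen-2-yl gives a 3.2-fold higher number from compound 1 to compound 4 (0.51 log units; beyond the scatter) so a ring with sulfur in place of nitrogen moves the number up at this position, not down. Set against pyridin-2-yl, the same group gives a 1.0-fold higher number from compound 2 to compound 4 (0.01 log units; within the scatter) and the two cannot be told apart here. Among compounds 1, 2 and 4, which differ only in this group, pyridin-3-yl alone gives the lower number.

No evidence at hand explains these steps. On these data alone, how a plain phenyl ring or a thiophen-3-yl group would read at this position remains open.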